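Open-chain replacement at the ring carbon of compound 1

The source may report more compounds than this note shows. Statements on the series, on what has been measured and on what is new or still open speak of the compounds shown alone.

Measured so far, in a functional assay on THP-1 cells (Homo sapiens), read by MTT assay, with a stated time of 4 days; a higher number here means that more compound is needed for the effect, a lower number that less compound is needed:
- compound 1 `CC[C@H]1OC(=O)O[C@@]1(C)[C@@H]1OC(=O)[C@H](C)[C@@H](O)[C@H](C)[C@@H](O[C@@H]2O[C@H](C)C[C@H](N(C)C)[C@H]2OC(C)=O)[C@@]2(C)C[C@@H](C)[C@H](O2)[C@@H]1C` gives 55.7 uM
- compound 2 `CC[C@@H]1O[C@@]1(C)[C@@H]1OC(=O)[C@H](C)[C@@H](O[C@H]2C[C@@](C)(OC)[C@@H](O)[C@H](C)O2)[C@H](C)[C@@H](O[C@@H]2O[C@H](C)C[C@H](N(C)C)[C@H]2O)[C@@]2(C)C[C@@H](C)[C@H](O2)[C@@H]1C` gives 10.2 uM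
- compound 3 `CC[C@@H](OC(C)=O)[C@@](C)(O)[C@@H]1OC(=O)[C@H](C)[C@@H](O[C@H]2C[C@@](C)(OC)[C@@H](O)[C@H](C)O2)[C@H](C)[C@@H](O[C@@H]2O[C@H](C)C[C@H](N(C)C)[C@H]2O)[C@@]2(C)C[C@@H](C)[C@H](O2)[C@@H]1C` gives 7.7 uM

Compound 1 stands highest of the three numbers in this assay ; its nearest neighbour is compound 2, and compound 3 lies furthest from it, both beyond the scatter.

The next compound is compound 4 `CC[C@@H](O)[C@@](C)(O)[C@@H]1OC(=O)[C@H](C)[C@@H](O)[C@H](C)[C@@H](O[C@@H]2O[C@H](C)C[C@H](N(C)C)[C@H]2OC(C)=O)[C@@]2(C)C[C@@H](C)[C@H](O2)[C@@H]1C`. It differs from compound 1 in one place: a group of 7 heavy atoms (5 carbon, 2 oxygen; no ring) in place of a group of 9 heavy atoms (6 carbon, 3 oxygen; one five-membered non-aromatic ring with 2 hetero atoms), on a saturated ring carbon.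

Going by the values given here, only one measured step bears on a change of this kind: a 1.3-fold lower number from compound 2 to compound 3 (0.12 log units; within the scatter). There a small ring on a saturated ring carbon gave way to an open-chain group, and the number hardly moved. The change from compound 1 to compound 4 likewise opens a ring at a saturated ring carbon and puts an open-chain group in its place, although the rest of the core differs from that of compounds 2 and 3, so the comparison is loose. No step beyond the scatter is therefore expected in this assay , and the estimated step is a 1.2-fold lower number from compound 1 to compound 4 (0.09 log units; within the scatter).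

Compound 4 is expected to give about 45 uM, within a range of 18 uM to 110 uM.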

Compound 4, concentration for half-maximal effect: > 100 uM
Compound 4 ended at the assay's limit; the forecaster's own chance of this, stated with the estimate: 10%; middle value at least 2.2-fold (0.34 log units) away from the limit.
By their numbers in this assay, from the lowest: compounds 3 and 2 (each within the scatter of the next); then compound 1. At a limit, above all of these: compound 4.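

The value of compound 4 in this assay is a limit of the assay and not a number: the limit of > 100 uM in this assay, at which 1 of the 4 values shown sits. On the core of compound 1, the open-chain group in place of the five-membered ring gives an at least 1.7-fold higher number from compound 1 to compound 4 (0.25 log units; that floor lies within the scatter), so only a floor is known, that floor does not clear the scatter, and the true size of the step cannot be read. The earlier step, a 1.3-fold lower number from compound 2 to compound 3 (0.12 log units; within the scatter), also replaced a ring with an open chain on a saturated ring carbon, but it stayed within the scatter on a different core; compound 4 adds only that, at this ring carbon next to the ring oxygen, the number does not fall on opening the five-membered ring and may rise by an unknown amount.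

On these data alone, it remains open whether a higher number follows from the loss of the ring itself or from the hydrogen-bond donors of the entering group. An open chain on the core of compound 1 that ends in a methyl ether or an amine would separate these two readings, and a value for such a compound below the limit would also give a step of readable size.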